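This account rests on a few compounds, and the source may have more. Where it says the series, first, only, none or still open, it means among the compounds named here.

Within the data shown here, compound 2 `Cc1n[nH]c(C(=O)O)c1Cc1cccc(C(=O)O)c1` gives 3% in an assay on isolated protein for inhibition of 2-Hydroxyacid oxidase 2 (Homo sapiens), tested at 1 uM (a lower number here means a weaker effect, a higher number a stronger effect of the compound at the concentration tested), and the only other number, that of compound 1 `Cc1n[nH]c(C(=O)O)c1Cc1cccc(-c2ccccc2F)c1` at 5%, lies within the scatter of it. Among the measured compounds shown here, the single measured step is a number 2 percentage points lower from compound 1 to compound 2 (within the scatter), for carboxy in place of 2-fluorophenyl on an aromatic carbon. Compound 3 `Cc1n[nH]c(C(=O)O)c1Cc1cccc(C#N)c1` differs from compound 2 by cyano in place of carboxy on an aromatic carbon. For the measured compounds named here, no measured step exchanges carboxy for cyano, and the one step seen stayed within the scatter, so the expected step is no change at the digits printed from compound 2 to compound 3 (within the scatter), none beyond the scatter. Compound 3 is therefore estimated at 3%, ranging from 0% to 12%.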

Compound 3, a percentage reported as inhibition, at one concentration (the size of the read-out at that concentration, not a potency): 6%
Estimate against measurement, compound 3: 3 percentage points below, and the stated range covers the measured number.
By their numbers in this assay, from the lowest: compounds 2, 1 and 3 (each within the scatter of the next).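

In this assay the exchange of carboxy for cyano gives a number 3 percentage points higher from compound 2 to compound 3 (within the scatter) and the exchange of 2-fluorophenyl for cyano gives a number 1 percentage points higher from compound 1 to compound 3 (within the scatter) at this aromatic carbon. Removing the hydrogen-bond donor of the carboxy thus leaves the read-out within the scatter, as did the earlier exchange of 2-fluorophenyl for carboxy. Nothing available explains why these three groups give such close numbers. As far as these compounds go, whether an amine, a methoxy group or a longer chain here would give a number beyond the scatter remains open. So does whether any group at this position matters at all.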